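Two Benzamides and a Simpler Phenol

The source may report more compounds than this note shows. Statements on the series, on what has been measured and on what is new or still open speak of the compounds shown alone.

Compound 1 `Cc1c(OC2CCN(C)CC2)ccc2cc(NC(=O)c3ccc(O)c(CCC(C)C)c3)c(=O)oc12`: 600 nM
Compound 2 `CC(=O)Oc1ccc(C(=O)Nc2cc3ccc(OC4CCN(C)CC4)c(C)c3oc2=O)cc1Cl`: 3500 nM

Among the measured compounds shown here, in a functional assay on SK-BR-3 cells (Homo sapiens) for antiproliferative activity (a lower number here means a stronger inhibitor, a higher number a weaker inhibitor), compound 2 gives 3500 nM, the higher of the two numbers measured so far. Its nearest neighbour on this scale, compound 1, gives 600 nM, and the gap between the two lies beyond the usual scatter of repeated measurements.

The next compound to be tested is compound 3 `Cc1c(OC2CCN(C)CC2)ccc2cc(NC(=O)c3ccc(O)cc3)c(=O)oc12`. It departs from compound 2 at a single place, with 4-hydroxyphenyl in place of 4-acetoxy-3-chlorophenyl on a carbonyl carbon. For the measured compounds named here, no measured pair shows this change on its own, so the data offer no direct guide to its effect.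

In this assay, no step beyond the scatter is expected, in either direction. Going by the values given here, compound 3 is expected to stay closer to compound 2 at 3500 nM than to compound 1 at 600 nM, though this remains a cautious expectation resting on only two values. The estimated change is a 1.2-fold lower number from compound 2 to compound 3 (0.07 log units; within the scatter). The estimated value for compound 3 is 3000 nM, with an expected range from 900 nM to 10000 nM.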

Compound 3, half-maximal inhibitory concentration: 840 nM
Beside the measured number, compound 3's estimate is 3.6-fold (0.55 log units) above it; the whole stated range lies above it.
By their numbers in this assay, from the lowest: compounds 1 and 3 (each within the scatter of the next); then compound 2.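

In this assay, the group on the carbonyl carbon clearly matters: replacing 4-acetoxy-3-chlorophenyl with 4-hydroxyphenyl gives a 4.2-fold lower number from compound 2 to compound 3 (0.62 log units; beyond the scatter) and places this change beyond the scatter. The isopentyl group on the aromatic carbon behaves differently, since hydrogen in its place gives a 1.4-fold higher number from compound 1 to compound 3 (0.15 log units; within the scatter) and so leaves compound 1 and compound 3 within the scatter of each other, which means that this chain is not needed to hold the activity seen with the 4-hydroxyphenyl amide. Nothing available here explains why one step moves the number beyond the scatter and the other does not.

On these data alone, what stays open is which part of the first change carries the step, as the chlorine and the acetoxy group leave together and the hydroxyl enters in the same exchange, so only a ring keeping the chlorine with a hydroxyl, or the acetoxy group without the chlorine, could separate them. As far as these compounds go, it is also open whether an amine or a carboxylic acid could stand in for the hydroxyl on this ring, and whether a chain longer than isopentyl would stay within the scatter as well.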